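This account rests on a few compounds, and the source may have more. Where it says the series, first, only, none or still open, it means among the compounds named here.

Measured so far: compound 1 `COc1cc(C)cc(-c2c(-c3ccnc(-c4ccc(C(C)=O)cc4)c3)cnn2CC#N)c1` with 85%, and compound 2 `COc1cc(C)cc(-c2nn(CC#N)cc2-c2ccnc(-c3ccc(N(C)C)cc3)c2)c1` with -22%.

In a functional assay on SK-MEL-5 cells (Homo sapiens) for cytotoxicity, read by sulforhodamine B assay, with a stated time of 48 h, tested at 100 nM (on this read-out higher numbers stand for a weaker effect at the one concentration tested and lower numbers for a stronger effect), compound 1 gives 85%, the higher of the two numbers; compound 2 stands far lower in this assay, a gap beyond the usual scatter. Compound 3 `COc1cc(C)cc(-c2c(-c3ccnc(-c4ccc(N(C)C)cc4)c3)cnn2CC#N)c1` has not yet been measured. It differs from compound 1 in one place: dimethylamino in place of acetyl on an aromatic carbon. Because compound 2, which also carries dimethylamino, gives -22%, a large step downward is expected, well beyond the scatter. The expected step is a number 75 percentage points lower from compound 1 to compound 3 (beyond the scatter). For compound 3 the estimate in this assay is 10%, within a range from -30% to 55%.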

Compound 3, a percentage reported as activity, at one concentration (the size of the read-out at that concentration, not a potency): -21%
Beside the measured number, compound 3's estimate is 31 percentage points above it; measured number inside the range.
By their numbers in this assay, from the lowest: compounds 2 and 3 (each within the scatter of the next); then compound 1.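

In this assay, exchanging 4-acetylphenyl for 4-(dimethylamino)phenyl gives a number 106 percentage points lower from compound 1 to compound 3 (beyond the scatter), so the read-out depends strongly on the group at this position. Among the compounds shown here, this is the first step between compounds that differ in one place, and it isolates this single change on an otherwise unchanged core. Nothing at hand explains the size of the step.

From the compounds shown here alone, whether a smaller amine such as methylamino, a methoxy group or a carboxylic acid at this position would read like compound 3 or like compound 1 remains open. So does whether a group of the same size as dimethylamino would give a similar read-out.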